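The compounds below may be only part of what the source reports. "The series", "measured", "known", "first", "only" and "open" are said of these compounds alone.

Of the compounds shown here, two built on the shared core have numbers so far in an in vitro ADME assay on microsomes from liver (Homo sapiens) for metabolic stability, tested at 1 uM; on this read-out higher numbers stand for a longer-lived compound and lower numbers for a shorter-lived compound. Compound 1 (`Cc1cc(/C=C/C#N)cc(C)c1Oc1cc(Nc2ccc(C#N)cc2)c(N)cc1[N+](=O)[O-]`) gives 0.797 h, and compound 2 (`Cc1cc(/C=C/C#N)cc(C)c1Oc1cc(Nc2ccc(C#N)cc2)c(N)cc1C(F)(F)F`) gives 0.75 h. Within the data shown here, compound 2 therefore stands level with the only other compound measured, with no real difference between them.

The next structure is compound 3 (`CNC(=O)c1cc(N)c(Nc2ccc(C#N)cc2)cc1Oc1c(C)cc(/C=C/C#N)cc1C`), which carries methylcarbamoyl in place of trifluoromethyl on an aromatic carbon. Among the measured compounds shown here, only one measured step bears on this change: a 1.1-fold lower number from compound 1 to compound 2 (0.03 log units; within the scatter). That step put trifluoromethyl in place of nitro on the same aromatic carbon, and it was small. It is thin evidence, however, as it comes from a single pair of compounds and neither of them carries methylcarbamoyl. For the measured compounds named here, no measurement yet shows what this group does to the number, so no direction can be argued from the data, and no step beyond the scatter is expected, though with real uncertainty. The expected move is no change at the digits printed from compound 2 to compound 3 (within the scatter). For compound 3 the estimated value is 0.75 h, with an expected range from 0.3 h to 1.8 h.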

Compound 3, half-life: 0.747 h
Beside the measured number, compound 3's estimate is 1.0-fold (0.00 log units) above it; low and high end bracket the measured number.
By their numbers in this assay, from the lowest: compounds 3, 2 and 1 (each within the scatter of the next).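

In this assay the exchange of trifluoromethyl for methylcarbamoyl gives a 1.0-fold lower number from compound 2 to compound 3 (0.00 log units; within the scatter) and so the two compounds stand level, even though the entering group carries a hydrogen-bond donor and a hydrogen-bond acceptor and the leaving group carries neither. Measured against nitro the picture is the same: the exchange gives a 1.1-fold lower number from compound 1 to compound 3 (0.03 log units; within the scatter) and this matches the earlier step, a 1.1-fold lower number from compound 1 to compound 2 (0.03 log units; within the scatter) and so three quite different groups on this aromatic carbon now stand level. For these three compounds, then, the half-life does not depend on which of the three groups sits at this place, but no measurement shown here explains why.

On these data alone, whether that tolerance extends further stays open: a carboxylic acid, a basic amine or a longer chain on the same aromatic carbon could still read apart from these three. All three compounds also share the (4-cyanophenyl)amino group and the amino group, so what those two groups contribute to the half-life cannot be told from these numbers.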